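A few compounds are considered here, and "the series" means these few. Any claim that something is new, unique, unknown or untested is made for them only; others in the source may bear on it.

In a functional assay on SW480 cells (Homo sapiens) for antiproliferative activity, read by sulforhodamine B assay, with a stated time of 48 h (on this read-out lower numbers stand for stronger inhibition and higher numbers for weaker inhibition), compound 1 (`COc1cccc(/C=C/C(=O)C(=Cc2cc(OC)c(OC)c(OC)c2)C(=O)/C=C/c2cccc(OC)c2OC)c1OC`) gives 650 nM, compound 2 (`COc1cc(OC)c(C=C(C(=O)/C=C/c2cccc(OC)c2OC)C(=O)/C=C/c2cccc(OC)c2OC)c(OC)c1`) gives 840 nM and compound 3 (`COc1ccc(OC)c(/C=C/C(=O)C(=Cc2ccc(O)c(OC)c2)C(=O)/C=C/c2cc(OC)ccc2OC)c1`) gives 410 nM. Compound 3 stands within the scatter of compound 1 and beyond the scatter on the lower side of compound 2. Compound 4 (`COc1ccc(OC)c(/C=C/C(=O)C(=Cc2ccc(O)c(F)c2)C(=O)/C=C/c2cc(OC)ccc2OC)c1`) differs from compound 3 in one place: fluoro in place of methoxy on an aromatic carbon. This is fluoro in place of methoxy, ortho to a hydroxy group. Among the measured compounds shown here, the only measured step, a 1.3-fold higher number from compound 1 to compound 2 (0.11 log units; within the scatter), exchanges one trimethoxyphenyl for another, and no measured pair carries this change. Going by these compounds, no step beyond the scatter is therefore expected in this assay, and the direction stays open. The estimated step is a 1.2-fold higher number from compound 3 to compound 4 (0.07 log units; within the scatter). Compound 4 is estimated at 480 nM, with an expected range of 200 nM to 1150 nM.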

Compound 4, half-maximal inhibitory concentration: 510 nM
Compound 4: the middle estimate sits 1.1-fold (0.03 log units) below what was measured; the range from low to high includes it.
By their numbers in this assay, from the lowest: compounds 3, 4, 1 and 2 (each within the scatter of the next, the first and the last beyond it).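

In this assay, fluoro in place of methoxy, ortho to a hydroxy group, gives a 1.2-fold higher number from compound 3 to compound 4 (0.09 log units; within the scatter). Among the compounds shown here, this is the first measured change at this position: 4-hydroxy-3-methoxyphenyl can give way to 3-fluoro-4-hydroxyphenyl without a step beyond the scatter, so a methoxy group is not required here to stay within the scatter of compound 3. Nothing available explains the size of this step. Still open, going by these compounds, is how an amine or a longer alkoxy chain would read at this position, and whether the step would stay this small without the hydroxy group.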